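Swapping fluoro for bromo in compound 2

The compounds below may be only part of what the source reports. "The series", "measured", "known", "first", "only" and "open" are said of these compounds alone.

- compound 1 `Fc1ccc(C2=NN(C3=NC(c4ccccc4)CS3)C(c3cccc4ccccc34)C2)cc1` gives 12400 nM
- compound 2 `O=C1CSC(N2N=C(c3ccc(F)cc3)CC2c2cccc3ccccc23)=N1` gives 11300 nM
- compound 3 `O=C1CSC(N2N=C(c3ccc(Br)cc3)CC2c2cccc3ccccc23)=N1` has not yet been measured

Among the compounds with values here, in a functional assay on HeLa cells (Homo sapiens) for inhibition, read by CCK-8 assay, with a stated time of 48 h (on this read-out higher numbers stand for weaker inhibition and lower numbers for stronger inhibition), compound 2 gives 11300 nM and lies within the scatter of compound 1, the only other compound with a number. Compound 3 differs from compound 2 by bromo in place of fluoro on an aromatic carbon in one change: bromo in place of fluoro on an aromatic carbon, para to a large group. Within the data shown here, only one measured step exists (a 1.1-fold lower number from compound 1 to compound 2 (0.04 log units; within the scatter)) and it lies within the scatter. Among the measured compounds shown here, that step swaps the group on an amine nitrogen in a ring, so it bears only loosely on this change, and no measured step covers the 4-fluorophenyl to 4-bromophenyl swap. As far as these compounds go, no step beyond the scatter is therefore expected in this assay and the direction stays open. The expected step is small (a 1.3-fold lower number from compound 2 to compound 3 (0.10 log units; within the scatter)) and the estimate is wide. Compound 3 is estimated at 9000 nM (range 3500 nM to 22000 nM).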

Compound 3, half-maximal inhibitory concentration: 5810 nM
For compound 3 the middle estimate is 1.5-fold (0.19 log units) above the measured one; measured number inside the range.
By their numbers in this assay, from the lowest: compounds 3, 2 and 1 (each within the scatter of the next, the first and the last beyond it).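

In this assay, the swap of 4-fluorophenyl to 4-bromophenyl gives a 1.9-fold lower number from compound 2 to compound 3 (0.29 log units; within the scatter). Within the data shown here, this is the first measured change on this aromatic carbon, para to a large group, as the earlier step concerned only the group on the amine nitrogen in a ring. It shows that, on this read-out, compound 2 and compound 3 cannot be told apart, so exchanging fluoro for bromo at this position does not carry the number beyond the scatter. No evidence on the cause of this result is available.

The compounds shown leave open whether chloro, a methoxy group or an amine on this aromatic carbon would also stay within the scatter of compound 2. As far as these compounds go, it also remains open how bromo would read with the group of compound 1 on the amine nitrogen.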